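This account rests on a few compounds, and the source may have more. Where it says the series, first, only, none or still open, it means among the compounds named here.

Measured in an ADME assay on HepG2 cells (Homo sapiens) for cytotoxicity, read by MTT assay, with a stated time of 7 days; a higher number here means a weaker inhibitor, a lower number a stronger inhibitor:
- compound 1 `COc1ccc(OC)c(C2CC(c3ccc(O)cc3)=NN2C(=O)c2cccnc2)c1`: 56800 nM
- compound 2 `O=C(c1cccnc1)N1N=C(c2ccc(O)cc2)CC1c1ccc([N+](=O)[O-])cc1`: 18600 nM

Compound 2 holds the lower of the two numbers in this assay. Compound 3 `O=C(c1cccnc1)N1N=C(c2ccc(O)cc2)CC1c1ccc(F)cc1` departs from it by fluoro in place of nitro on an aromatic carbon. For the measured compounds named here, the one measured step bearing on this, a 3.1-fold lower number from compound 1 to compound 2 (0.48 log units; beyond the scatter), is modest and also swaps the same aryl group. It offers no trend for this exchange, so no step beyond the scatter is expected. The expected step is a 1.3-fold higher number from compound 2 to compound 3 (0.13 log units; within the scatter). For compound 3 the estimated value is 25000 nM, with an expected range of 10000 nM to 60000 nM.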

Compound 3, half-maximal inhibitory concentration: 52400 nM
The estimate for compound 3 lay 2.1-fold (0.32 log units) below the measured number; the range from low to high includes it.
By their numbers in this assay, from the lowest: compound 2; then compounds 3 and 1 (each within the scatter of the next).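

In this assay the aromatic carbon para to a large group responds to the exchange of nitro for fluoro, with a 2.8-fold higher number from compound 2 to compound 3 (0.45 log units; beyond the scatter) as the first step read at this position alone. The 4-fluorophenyl and 2,5-dimethoxyphenyl groups stand level, with a 1.1-fold lower number from compound 1 to compound 3 (0.04 log units; within the scatter) between them, so among these three compounds only the 4-nitrophenyl group stands apart, at the lower number. Going by these compounds, whether an amine or a carboxylic acid on this carbon would fall with nitro or with fluoro stays open. On these data alone, what underlies the gap between nitro and fluoro also stays open, as no supporting data bear on it.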